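Cyclobutyl in Place of Fluoro: An Estimate for Compound 4

This account rests on a few compounds, and the source may have more. Where it says the series, first, only, none or still open, it means among the compounds named here.

Compound 1 `Cc1cc(F)c(S(C)(=O)=O)cc1C(=O)N=C(N)N`: 44 nM
Compound 2 `CS(=O)(=O)c1cc(C(=O)N=C(N)N)c(F)cc1F`: 630 nM
Compound 3 `Cc1c(C(=O)N=C(N)N)ccc(Cl)c1S(C)(=O)=O`: 1300 nM

In a functional assay for inhibition of sodium/hydrogen exchanger (Oryctolagus cuniculus) (on this read-out lower numbers stand for stronger inhibition and higher numbers for weaker inhibition), compound 1 gives 44 nM, the lowest of the three numbers measured. Going by the values given here, the nearest to it is compound 2, and that gap is the one step measured between compounds differing in a single place: a 14-fold higher number from compound 1 to compound 2 (1.16 log units; beyond the scatter). Among the compounds with values here, compound 3, with a chloro on its core and a different arrangement of the methyl and methylsulfonyl groups, gives 1300 nM in this assay, further still from compound 1; no single-point step connects it to the others.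

Compound 4 `Cc1cc(C2CCC2)c(S(C)(=O)=O)cc1C(=O)N=C(N)N` has not been measured. It differs from compound 1 in one place: cyclobutyl in place of fluoro on an aromatic carbon. Within the data shown here, no measured step covers this exchange. Among the measured compounds shown here, the one step available, from compound 1 to compound 2, puts fluoro in for methyl on a different aromatic carbon and was large, but it does not tell what cyclobutyl does where fluoro stood ortho to the methylsulfonyl group. For the measured compounds named here, with no direct precedent, the step of a 2.5-fold higher number from compound 1 to compound 4 (0.40 log units; beyond the scatter) is expected to be modest, tending toward a higher number, with a wide range either way. Compound 4 is therefore estimated to give 110 nM in this assay, between 25 nM and 600 nM.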

Compound 4, half-maximal inhibitory concentration: 8.2 nM
For compound 4 the middle estimate is 13-fold (1.13 log units) above the measured one; measured number below the stated range.
By their numbers in this assay, from the lowest: compound 4; then compound 1; then compound 2; then compound 3.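

In this assay, the position ortho to a methylsulfonyl group accepts far more than a single fluorine: cyclobutyl, with 4 heavy atoms and one four-membered non-aromatic ring, replaces fluoro, with 1 heavy atom, and the step is a 5.4-fold lower number from compound 1 to compound 4 (0.73 log units; beyond the scatter), so the number falls rather than rises. Going by these compounds alone, the one earlier single-place step lay at a different aromatic carbon and raised the number, whereas this one shows that fluoro is not needed at this position for a low number, and that a low number here does not depend on adding any hydrogen-bond donor, hydrogen-bond acceptor or net charge. Nothing in the data available accounts for this step.

The compounds shown compare only fluoro and cyclobutyl at this position, so it remains open whether the lower number would hold for a cyclopropyl or cyclopentyl ring, a longer open chain such as butyl, an amine or a carboxylic acid. From the compounds shown here alone, it is also open whether cyclobutyl would give a similar step with fluoro in place of the methyl group meta to this position, the change that raised the number from compound 1 to compound 2.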